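A few compounds are considered here, and "the series" means these few. Any claim that something is new, unique, unknown or untested is made for them only; others in the source may bear on it.

Working notes on the series in an assay on cells for inhibition of MAP kinase-interacting serine/threonine-protein kinase 1 (Homo sapiens), read by mobility shift assay, with stated times of 10 min and 60 min, in the presence of a further agent that is not named here; a lower number here means a stronger inhibitor, a higher number a weaker inhibitor. Compound 1 `CNC(=O)c1cncc(-c2ccc(C(N)=O)c(OC(C)C)c2)c1` gives 1900 nM in this assay. For the measured compounds named here, compound 2 `CCOc1cc(-c2cccnc2)ccc1C(N)=O` gives 2200 nM in this assay; this is the higher of the two numbers so far, but compound 1 sits only a small distance away, within the scatter, so the two compounds are not ordered against each other on these data.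

Compound 3 `NC(=O)c1ccc(-c2cccnc2)cc1OC1CCCCC1` is the next compound to be run. It differs from compound 2 in one place: cyclohexyl in place of ethyl on an oxygen on an aromatic ring. Going by the values given here, no measured pair in the set isolates this change, so there is no step to lean on. With nothing to anchor it, the expected movement from compound 2 to compound 3 is a 1.2-fold lower number from compound 2 to compound 3 (0.09 log units; within the scatter), that is, no step beyond the usual scatter in either direction, with the range kept wide. Compound 3 is therefore estimated at 1800 nM in this assay, with a range from 500 nM to 6000 nM.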

Compound 3, half-maximal inhibitory concentration: 1500 nM
Beside the measured number, compound 3's estimate is 1.2-fold (0.08 log units) above it; the range from low to high includes it.
By their numbers in this assay, from the lowest: compounds 3, 1 and 2 (each within the scatter of the next).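

Cyclohexyl in place of ethyl on an oxygen on an aromatic ring gives the first single-change step of the series in this assay (a 1.5-fold lower number from compound 2 to compound 3 (0.17 log units; within the scatter)). This position therefore accepts the larger cyclohexyl, with its six-membered non-aromatic ring of carbon only, without a step beyond the scatter, so the size of this group is not shown to move the number in this pair. No measurement on hand bears on the reason for this result.

One step at one position gives no trend, and whether the same holds with another core substitution is open, as compound 1 carries no single-change link to compound 2 or compound 3. Also open, from the compounds shown here alone, is whether an amine, a carboxylic acid or a longer chain on this oxygen would give a step beyond the scatter.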